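The source may report more compounds than this note shows. Statements on the series, on what has been measured and on what is new or still open speak of the compounds shown alone.

Measured in a functional assay on L1210 cells (Mus musculus) for antiproliferative activity, with a stated time of 72 h; on this read-out lower numbers stand for an effect already at smaller amounts and higher numbers for an effect only at larger amounts of compound:
Compound 1 `Cc1cn([C@@H]2O[C@H](CO)[C@@H](CN)[C@H]2O)c(=O)[nH]c1=O`: > 100 uM
Compound 2 `Cc1cn([C@@H]2O[C@H](CO)[C@@H](CN)[C@@H]2O)c(=O)[nH]c1=O`: > 100 uM

Both entries are limits of the assay and not numbers. Compound 2 therefore has no place on a numerical scale, and it shares the limit of > 100 uM in this assay, at which 2 of the 2 values shown sit, with compound 1. Going by the values given here, the one measured step is a step that the two limits leave unreadable from compound 1 to compound 2, and it reflects (the fact that compounds 1 and 2 differ only in the configuration as drawn).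

Compound 3 `Cc1cn([C@H]2C[C@H](CN)[C@@H](CO)O2)c(=O)[nH]c1=O` is reached from compound 2 by a single change: hydrogen in place of hydroxy on a saturated ring carbon. The carbon that loses the hydroxy is the stereocentre whose configuration separates compound 1 from compound 2. Among the compounds with values here, neither configuration gives a readable effect in this assay, so no measured step supplies a size for removing the hydroxy. With only a step that the two limits leave unreadable from compound 1 to compound 2 to draw on, no clear step in either direction is expected, and a further limit is the most likely report, although a gain in potency cannot be ruled out. The expected step is a step that the limit leaves unreadable from compound 2 to compound 3. Compound 3 is estimated at 150 uM. The expected range for compound 3 runs from 40 uM to 400 uM.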

Compound 3, concentration for half-maximal effect: > 100 uM
Compound 3: a limit, no number; the forecaster's own chance of this, stated with the estimate: 80%; the middle value is on the limit's open side.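

In this assay compound 3 gives > 100 uM, which is again a limit and not a number. Going by these compounds alone, no step can therefore be read from compound 1 or compound 2 to compound 3. The compounds shown leave open whether the hydroxy, in either configuration, has any bearing on the antiproliferative effect, as none of the three gives a number.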